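The source may hold more compounds than are shown below. What is called first, only, known or untested is meant among the compounds shown, and "the series" means these compounds.

Measured compounds:
compound 1 `Cc1cc(C)cc(CNc2cncc(-c3cc(C)cc(C)c3)c2N2CCC(N)CC2)c1` — 0.8 nM
compound 2 `Cc1cc(C)cc(-c2cncc(-c3nc4cc(Cl)ccc4[nH]3)c2N2CCC(N)CC2)c1` — 0.015 nM
compound 3 `Cc1cc(C)cc(-c2cncc(-c3nc4cc(C)ccc4[nH]3)c2N2CCC(N)CC2)c1` — 0.013 nM

In a functional assay on CHO-K1 cells for agonist activity at somatostatin receptor type 2 (Homo sapiens), read by cAMP accumulation, with a stated time of 30 min (a lower number here means that less compound is needed, a higher number that more compound is needed for the effect), compound 3 gives the lowest number of the three. Its step from compound 2 is a 1.2-fold lower number from compound 2 to compound 3 (0.06 log units; within the scatter), so the two cannot be ordered. Against compound 1 the gap is large: a 62-fold lower number from compound 1 to compound 3 (1.79 log units; beyond the scatter).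

Compound 4 `Cc1cc(C)cc(OCc2cncc(-c3cc(C)cc(C)c3)c2N2CCC(N)CC2)c1` is not yet measured. The change from compound 3 is (3,5-dimethylphenoxy)methyl in place of 5-methyl-1H-benzimidazol-2-yl on an aromatic carbon. Among the compounds with values here, no measured pair covers this exact exchange. Within the data shown here, the steps that bear on it are a 53-fold lower number from compound 1 to compound 2 (1.73 log units; beyond the scatter) and a 62-fold lower number from compound 1 to compound 3 (1.79 log units; beyond the scatter): each swap of the (3,5-dimethylbenzyl)amino group of compound 1 for a 1H-benzimidazol-2-yl group lowered the number by a large amount. Compound 4 removes the benzimidazole again and carries a substituent that, like that of compound 1, presents a 3,5-dimethylphenyl on a one-atom linker. The expectation is therefore that the gain seen in those two steps is lost, and the estimated step is a 77-fold higher number from compound 3 to compound 4 (1.89 log units; beyond the scatter), upward. Compound 4 is expected at 1 nM, with a range from 0.2 nM to 5 nM.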

Compound 4, half-maximal effective concentration: 3.7 nM
Estimate against measurement, compound 4: 3.7-fold (0.57 log units) below; the range from low to high includes it.
By their numbers in this assay, from the lowest: compounds 3 and 2 (each within the scatter of the next); then compound 1; then compound 4.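

In this assay, replacing either benzimidazole with (3,5-dimethylphenoxy)methyl gives a 280-fold higher number from compound 3 to compound 4 (2.45 log units; beyond the scatter) and a 250-fold higher number from compound 2 to compound 4 (2.39 log units; beyond the scatter), although the groups that leave and the group that enters each hold 10 heavy atoms, so this position responds strongly to the type of group and not only to its heavy-atom count. Among the two groups that lack a benzimidazole, the exchange still registers, with a 4.6-fold higher number from compound 1 to compound 4 (0.67 log units; beyond the scatter), so the position also distinguishes (3,5-dimethylphenoxy)methyl from (3,5-dimethylbenzyl)amino. No evidence on the origin of these steps is available.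

An N-methylbenzimidazol-2-yl or benzoxazol-2-yl group would help separate the role of the ring hydrogen-bond donor from that of the fused ring system. A (3,5-dimethylbenzyl)oxy group would show whether the difference between compound 1 and compound 4 follows the linker atom or its placement.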